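A few compounds are considered here, and "the series" means these few. Any claim that something is new, unique, unknown or untested is made for them only; others in the source may bear on it.

Compound 1, `CC(O)(CSc1cccc(C(F)(F)F)c1)C(=O)Nc1ccc(S(F)(F)(F)(F)F)cc1`, gives 18800 nM in a functional assay on VCaP cells (Homo sapiens) for antiproliferative activity, read by propidium iodide staining, with a stated time of 96 h; a lower number here means a stronger inhibitor, a higher number a weaker inhibitor.
Compound 2, `CC(O)(CSc1cc(C(F)(F)F)cc(C(F)(F)F)c1)C(=O)Nc1ccc(S(F)(F)(F)(F)F)cc1`, gives 19400 nM in this assay.
Compound 3, `CC(O)(CSc1cccc(C(F)(F)F)c1)C(=O)Nc1cccc(S(F)(F)(F)(F)F)c1`, gives 20200 nM in this assay.

All three numbers sit close together, none of them separated from the others by more than the usual scatter, so none can be called stronger or weaker than another. Compound 1 and compound 2 share one core and differ only by trifluoromethyl in place of hydrogen on an aromatic carbon. This change gave a 1.0-fold higher number from compound 1 to compound 2 (0.01 log units; within the scatter). Compound 3 is built from the same atoms as compound 1, joined differently; the difference between the two cores is not broken down here.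

Compound 4, `CC(O)(CSc1cc(C(F)(F)F)cc(C(F)(F)F)c1)C(=O)Nc1cccc(S(F)(F)(F)(F)F)c1`, has not yet been measured in this assay. It differs from compound 3 by trifluoromethyl in place of hydrogen on an aromatic carbon. This is the same change as the one between compound 1 and compound 2, made at a place described in identical terms, and it occurs twice among these compounds. Because the same change gave a 1.0-fold higher number from compound 1 to compound 2 (0.01 log units; within the scatter), the step is expected to be similarly small, about a 1.0-fold higher number from compound 3 to compound 4 (0.01 log units; within the scatter). Compound 4 is therefore estimated at 20500 nM, likely between 12000 nM and 35000 nM.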

Compound 4, half-maximal inhibitory concentration: 4000 nM
Beside the measured number, compound 4's estimate is 5.1-fold (0.71 log units) above it, and the stated range ends above it.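

On the core of compound 3, trifluoromethyl in place of hydrogen on an aromatic carbon gave a 5.1-fold lower number from compound 3 to compound 4 (0.70 log units; beyond the scatter) in this assay. The step seen on one core therefore did not predict the step on the other, so in this series the size of this change cannot simply be carried from one core to another: the same change on two cores in this assay, a 1.0-fold higher number (0.01 log units; within the scatter) from compound 1 to compound 2 and a 5.1-fold lower number (0.70 log units; beyond the scatter) from compound 3 to compound 4, 5.2-fold (0.72 log units) apart, beyond the scatter of two such steps

These two pairs show that the outcome of the change depends on the core that carries it, but they do not show why, nor how the change would behave on any further core.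

The compounds shown leave open whether another group at the same place, such as a nitrile, a chlorine atom or an amine, would also give a lower number on the core of compound 3. They also leave open whether any such group would move the number on the core of compound 1, where trifluoromethyl gave a step within the scatter.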